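This account rests on a few compounds, and the source may have more. Where it says the series, first, only, none or still open, it means among the compounds named here.

In a functional assay on MCF7 cells (Homo sapiens) for cytotoxicity, read by MTT assay, with a stated time of 48 h (a lower number here means a stronger inhibitor, a higher number a weaker inhibitor), the measured compounds stand as follows. Compound 1, `COc1ccc(CNC(=O)CSc2nc3ccc(NC(=O)c4ccccc4OC)cc3s2)cc1`, gives 9300 nM. Compound 2, `CNC(=O)CSc1nc2ccc(NC(=O)c3ccc(Cl)cc3)cc2s1`, gives 29400 nM. Compound 3, `CNC(=O)CSc1nc2ccc(NC(=O)c3ccc([N+](=O)[O-])cc3)cc2s1`, gives > 100000 nM, which is a limit of the assay and not a number.

Compound 3 therefore sits at the limit of > 100000 nM in this assay, at which 1 of the 3 values shown sits: this assay returns only a limit for it, with no number. For the measured compounds named here, the single step measured within the set is an at least 3.4-fold higher number from compound 2 to compound 3 (0.53 log units; beyond the scatter), a change in which the nitro group enters in place of chloro.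

Compound 4, `CNC(=O)CSc1nc2ccc(NC(=O)c3ccccc3OC)cc2s1`, has not yet been measured. It differs from compound 3 by 2-methoxyphenyl in place of 4-nitrophenyl on a carbonyl carbon. Going by the values given here, no measured step covers this exact change, but two facts bear on it. The step of an at least 3.4-fold higher number from compound 2 to compound 3 (0.53 log units; beyond the scatter) shows that the nitro compound lies at least modestly beyond the chloro compound, so leaving the nitro group is expected to move the number back down, toward a reported value. Compound 1, which also bears the 2-methoxyphenyl, gives 9300 nM, and compound 2 gives 29400 nM. Compound 4 is therefore expected to give 20000 nM (range 7000 nM to 60000 nM). That estimate means an expected step of an at least 5.0-fold lower number from compound 3 to compound 4 (0.69 log units; beyond the scatter), a lower number than the limit of compound 3.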

Compound 4, half-maximal inhibitory concentration: 23400 nM
Compound 4: the middle estimate sits 1.2-fold (0.07 log units) below what was measured, and the stated range covers the measured number.
By their numbers in this assay, from the lowest: compound 1; then compounds 4 and 2 (each within the scatter of the next). At a limit, above all of these: compound 3.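

On a carbonyl carbon whose other neighbours are an amide-type nitrogen, 2-methoxyphenyl in place of 4-nitrophenyl gives an at least 4.2-fold lower number from compound 3 to compound 4 (0.63 log units; beyond the scatter) in this assay, so moving away from the 4-nitrophenyl compound brings the reading off the limit of the assay that compound 3 holds: the limit of > 100000 nM in this assay, at which 1 of the 4 values shown sits. The two groups that give numbers at this place, 2-methoxyphenyl and 4-chlorophenyl, cannot be told apart, as a 1.3-fold lower number from compound 2 to compound 4 (0.10 log units; within the scatter) shows, so among the compounds shown only the 4-nitrophenyl group stands apart here. The other end of the molecule also gets its first reading, with hydrogen in place of 4-methoxyphenyl on a saturated chain carbon bound to an amide-type nitrogen giving a 2.5-fold higher number from compound 1 to compound 4 (0.40 log units; beyond the scatter), a modest change in which the compound carrying the 4-methoxyphenyl has the lower number.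

The compounds shown leave open how 4-methoxyphenyl, an unsubstituted phenyl or an aminophenyl would behave on the carbonyl carbon. They also leave open whether a longer chain or a carboxylic acid at the other end would lower the number further, and whether the step seen there would hold with 4-chlorophenyl on the carbonyl carbon.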